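The source may report more compounds than this note shows. Statements on the series, on what has been measured and on what is new or still open speak of the compounds shown alone.

Working notes on the series: in a functional assay on HCT-15 cells (Homo sapiens) for inhibition (a higher number here means a weaker inhibitor, a lower number a stronger inhibitor), compound 1 (`CCOC(=O)Nc1nc(=O)n(C2O[C@H](C(=O)O)[C@@H](O)[C@H]2O)cc1F`) gives 0.47 ug/mL and compound 2 (`O=C(Nc1nc(=O)n(C2O[C@H](C(=O)O)[C@@H](O)[C@H]2O)cc1F)Oc1ccccc1`) gives 0.39 ug/mL. Compound 2 therefore stands level with compound 1 within the scatter. Compound 3 (`O=C(Nc1nc(=O)n(C2O[C@H](C(=O)O)[C@@H](O)[C@H]2O)cc1F)OCc1ccccc1`) is the next to be measured. The change is benzyl in place of phenyl on an oxygen next to a carbonyl group. Within the data shown here, the one measured step at this oxygen is a 1.2-fold lower number from compound 1 to compound 2 (0.08 log units; within the scatter), so no step beyond the scatter is expected in this assay. The estimated step is a 1.1-fold higher number from compound 2 to compound 3 (0.03 log units; within the scatter). For compound 3 the expected value is 0.42 ug/mL, with an estimated range of 0.2 ug/mL to 0.9 ug/mL.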

Compound 3, half-maximal inhibitory concentration: 0.17 ug/mL
Estimate against measurement, compound 3: 2.5-fold (0.39 log units) above; measured number below the stated range.
By their numbers in this assay, from the lowest: compound 3; then compounds 2 and 1 (each within the scatter of the next).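

In this assay, the group on this oxygen next to a carbonyl group now shifts the number beyond the scatter: benzyl in place of phenyl gives a 2.3-fold lower number from compound 2 to compound 3 (0.36 log units; beyond the scatter), and phenyl in place of methyl on the saturated chain carbon gives a 2.8-fold lower number from compound 1 to compound 3 (0.44 log units; beyond the scatter). Ethyl and phenyl had stood level, so an aromatic ring on the oxygen does not by itself separate these compounds, whereas benzyl does, though only modestly. Nothing measured here accounts for the step. On these data alone, whether a phenethyl group on this oxygen lowers the number further, or a longer saturated chain such as butyl matches benzyl without an aromatic ring, stays open.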